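The source may report more compounds than this note shows. Statements on the series, on what has been measured and on what is new or still open speak of the compounds shown alone.

Measured in an ADME assay (liver) for metabolic stability, with Liver microsome (Rattus norvegicus) as the target, using microsomes; on this read-out higher numbers stand for fast clearance and lower numbers for slow clearance:
- Compound 1 `O=C(O)c1csc(-n2nc(-c3ccc(F)cc3)c3ccccc32)n1`: 278 mL/min/kg
- Compound 2 `O=C(O)c1csc(-n2nc(-c3ccc(Cl)cc3)c3ccccc32)n1`: 753 mL/min/kg
- Compound 3 `COc1ccc(-c2nn(-c3nc(C(=O)O)cs3)c3ccccc23)cc1`: 618 mL/min/kg

Compound 3 sits level with compound 2 at the upper end of this small set. The data show a 1.2-fold lower number from compound 2 to compound 3 (0.09 log units; within the scatter). Compound 1 stands apart from both, with a 2.7-fold higher number from compound 1 to compound 2 (0.43 log units; beyond the scatter) and a 2.2-fold higher number from compound 1 to compound 3 (0.35 log units; beyond the scatter).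

Compound 4 `O=C(O)c1csc(-n2nc(-c3ccc(C(F)(F)F)cc3)c3ccccc32)n1` carries trifluoromethyl in place of methoxy on an aromatic carbon, para to a large group (trifluoromethyl in place of methoxy on an aromatic carbon). The three measured steps all swap a group at this same place, so they are the ones that bear on the change. They are modest at most, and only the two steps away from fluoro go beyond the scatter. Compound 4 keeps no fluoro at this place as a lone atom, so it is expected to stay near compound 3, although a fall towards compound 1 cannot be ruled out. The expected step is a 1.1-fold higher number from compound 3 to compound 4 (0.02 log units; within the scatter), which would lie within the scatter. For compound 4 the estimated value is 650 mL/min/kg, with an expected range of 300 mL/min/kg to 1400 mL/min/kg.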

Compound 4, clearance: 809 mL/min/kg
Compound 4: the middle estimate sits 1.2-fold (0.10 log units) below what was measured, and the stated range covers the measured number.
By their numbers in this assay, from the lowest: compound 1; then compounds 3, 2 and 4 (each within the scatter of the next).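

In this assay, trifluoromethyl at this place on the aromatic ring does not separate from the groups already tested: the steps from methoxy (a 1.3-fold higher number from compound 3 to compound 4 (0.12 log units; within the scatter)) and from chloro (a 1.1-fold higher number from compound 2 to compound 4 (0.03 log units; within the scatter)) both stay within the scatter, even though methoxy carries a hydrogen-bond acceptor and trifluoromethyl carries none. Only the step from fluoro (a 2.9-fold higher number from compound 1 to compound 4 (0.46 log units; beyond the scatter)) goes beyond the scatter, so among these four compounds compound 1 alone stands apart, and no compound goes against this. Nothing given here explains why the fluoro compound stands apart from the other three. As far as these compounds go, whether a plain hydrogen, an amine or a nitrile at this place would group with fluoro or with the other three stays open. So does whether a longer chain there would give a number outside this range.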